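The source may report more compounds than this note shows. Statements on the series, on what has been measured and on what is new or still open speak of the compounds shown alone.

Measured so far:
Compound 1, `CSC[C@H](NC(=O)c1ccc(C#Cc2ccccc2)cc1)C(=O)NO`, gives in a physicochemical assay for lipophilicity (a higher number here means a more lipophilic compound, a lower number a more polar compound), a value of 3.
Compound 2, `CC(C)(NC(=O)c1ccc(C#Cc2ccccc2)cc1)C(=O)NO`, gives in this assay a value of 3.

Compound 2 stands level with compound 1 in this assay, the step of no change at the digits printed from compound 1 to compound 2 (within the scatter) lying within the scatter. Compound 3, `O=C(NC1(C(=O)NO)CCC1)c1ccc(C#Cc2ccccc2)cc1`, carries the change (1-(hydroxycarbamoyl)cyclobutyl in place of 1-(hydroxycarbamoyl)-1-methylethyl on an amide-type nitrogen). Going by the values given here, no measured step exchanges a chain for a ring on this nitrogen; the one step to hand shows only that a swap of similar size there left this assay unmoved. A small rise, at most near the edge of the scatter, is expected: a number 0.30 log units higher from compound 2 to compound 3 (within the scatter). Compound 3 is therefore estimated at 3.3, within 2.9 to 3.7.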

Compound 3, distribution coefficient: > 3
Compound 3 ended at the assay's limit; the forecaster's own chance of this, stated with the estimate: 2%; the middle value is on the limit's open side.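

Compound 3 gives > 3 in this assay, which is a limit of the assay and not a number. It is the first compound shown with a ring in the group on this amide-type nitrogen, and 1-(hydroxycarbamoyl)cyclobutyl there brings a number no lower from compound 2 to compound 3 (the limit leaves the size open) and a number no lower from compound 1 to compound 3 (the limit leaves the size open) though the size of both steps cannot be read. Only this compound stands at such a limit: the limit of > 3 in this assay, at which 1 of the 3 values shown sits.

Going by these compounds, the true value of compound 3 stays open. So does the reading in this assay if an amine or a longer chain is carried on this nitrogen.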